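Swapping methyl for chloro in serum protein binding

This account rests on a few compounds, and the source may have more. Where it says the series, first, only, none or still open, it means among the compounds named here.

Compound 1 `Cc1c[nH]c2c(N/C(N[C@H]3CCCCN(CC(=O)N4CCCC4)C3=O)=C(/C#N)C(=O)N(C)C)cccc12`: 80%
Compound 2 `CN(C)C(=O)/C(C#N)=C(\Nc1cccc2c(Cl)c[nH]c12)N[C@H]1CCCCN(CC(=O)N2CCCC2)C1=O`: 84%
Compound 3 `Cc1c[nH]c2c(N/C(=C\C#N)N[C@H]3CCCCN(CC(=O)N4CCCC4)C3=O)cccc12`: 80%

These values come from an ADME assay on a cell-free system (serum, Homo sapiens) for protein binding, using equilibrium dialysis, with a stated time of 4 h, tested at 10 uM. Compound 3 stands level with compound 1, and compound 2 lies within the scatter of both. Compound 4 `N#C/C=C(\Nc1cccc2c(Cl)c[nH]c12)N[C@H]1CCCCN(CC(=O)N2CCCC2)C1=O` has not yet been measured. It differs from compound 3 by chloro in place of methyl on an aromatic carbon, turning 3-methyl-1H-indol-7-yl into 3-chloro-1H-indol-7-yl. The same swap has been measured once, as a 1.3-fold lower unbound fraction from compound 1 to compound 2 (0.10 log units; within the scatter). Among the measured compounds shown here, with only this small step as a guide, no change beyond the scatter is expected in this assay. The expected step is a 1.3-fold lower unbound fraction from compound 3 to compound 4 (0.10 log units; within the scatter). Compound 4 is estimated at 84%, with an expected range from 76% to 90%.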

Compound 4, plasma protein binding: 84%
The estimate for compound 4 equals the measured number at the digits printed, and the stated range covers the measured number.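

On the core of compound 3, chloro in place of methyl gives a 1.3-fold lower unbound fraction from compound 3 to compound 4 (0.10 log units; within the scatter) in this assay. The swap had been seen on a single core and now reads the same on a second one: the same change on two cores in this assay, a 1.3-fold lower unbound fraction (0.10 log units; within the scatter) from compound 1 to compound 2 and a 1.3-fold lower unbound fraction (0.10 log units; within the scatter) from compound 3 to compound 4, 1.0-fold (0.00 log units) apart, within the scatter of two such steps

On both cores, then, methyl and chloro at this place on the five-membered aromatic ring cannot be told apart in this read-out. The compounds shown carry only these two groups here, so whether an amine, a carboxylic acid or a longer chain at the same place would move binding beyond the scatter remains open.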